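The source may hold more compounds than are shown below. What is called first, only, known or untested is meant among the compounds shown, and "the series" means these compounds.

Measured compounds in a functional assay on RCC4 cells (Homo sapiens) for inhibition, read by XTT assay, with a stated time of 4 days; a higher number here means a weaker inhibitor, a lower number a stronger inhibitor:
compound 1, `Cc1cccc(Nc2nc(-c3ccncc3)c(C)s2)c1`, 10000 nM
compound 2, `Cc1cccc(Nc2nc(-c3ccnc(-c4cnn(Cc5ccccc5)c4)c3)cs2)c1`, 2200 nM; 2240 nM (2 entries)
compound 3, `Cc1cccc(Nc2nc(-c3ccncc3C#CCN3CCN(C)CC3)cs2)c1`, 2600 nM; 2630 nM (2 entries)

Compound 1 stands at the largest number among the three shown in this assay, and its further entries carry no single number. The repeat entries of compound 2 (the several entries of compound 2 in this assay, 2200 nM; 2240 nM (2 entries)) and of compound 3 (the several entries of compound 3 in this assay, 2600 nM; 2630 nM (2 entries)) agree closely with each other.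

Compound 4, `Cc1cccc(Nc2nc(-c3ccncc3)c(C(=O)N(C)C)s2)c1`, differs from compound 1 by dimethylcarbamoyl in place of methyl on an aromatic carbon. Within the data shown here, no measured step resembles this change, so no size beyond the scatter is expected in this assay in either direction. Compound 4 is estimated at 10000 nM, between 3000 nM and 30000 nM, an expected step of no change at the digits printed from compound 1 to compound 4 (within the scatter).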

Compound 4, half-maximal inhibitory concentration: 16200 nM
For compound 4 the middle estimate is 1.6-fold (0.21 log units) below the measured one; measured number inside the range.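

Among these compounds, at the aromatic carbon next to the ring sulfur, this assay reads dimethylcarbamoyl in place of methyl as a 1.6-fold higher number from compound 1 to compound 4 (0.21 log units; within the scatter) and so gives the first step at this position. The larger group, which brings a hydrogen-bond acceptor, leaves the number within the scatter of the methyl compound. Nothing at hand gives a cause for this step.

From the compounds shown here alone, whether an amine, a carboxylic acid or a longer chain at this position would move the number beyond the scatter stays open. Also open, going by these compounds, is whether dimethylcarbamoyl behaves alike when the pyridin-4-yl group carries further substituents.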